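The compounds below may be only part of what the source reports. "The series", "measured", "known", "first", "only" and "open" are said of these compounds alone.

In a functional assay on PC-3 cells (Homo sapiens) for antiproliferative activity, read by MTT assay, with a stated time of 48 h (on this read-out higher numbers stand for weaker inhibition and lower numbers for stronger inhibition), compound 1 `O=C1c2ccccc2C(=O)N1c1nc(-c2ccc([N+](=O)[O-])cc2)cs1` gives 41800 nM. Compound 2 `O=C1c2ccc(F)cc2C(=O)N1c1nc(-c2ccccc2)cs1` gives 40200 nM in this assay; its number sits just under that of compound 1, yet the gap between the two lies within the scatter, so they stand together. Compound 3 `COc1ccc(-c2csc(N3C(=O)c4ccc(F)cc4C3=O)n2)cc1` differs from compound 2 by methoxy in place of hydrogen on an aromatic carbon. Among the compounds with values here, no measured pair shows this change, so no shift beyond the scatter is expected in either direction. Compound 3 is therefore estimated at 38000 nM, within a range from 13000 nM to 110000 nM. The step of a 1.1-fold lower number from compound 2 to compound 3 (0.02 log units; within the scatter) that this estimate means is expected to stay within the scatter.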

Compound 3, half-maximal inhibitory concentration: 41300 nM
The estimate for compound 3 lay 1.1-fold (0.04 log units) below the measured number, within the range that was stated.
By their numbers in this assay, from the lowest: compounds 2, 3 and 1 (each within the scatter of the next).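

With methoxy in place of hydrogen on an aromatic carbon, para to a large group, this assay shows a 1.0-fold higher number from compound 2 to compound 3 (0.01 log units; within the scatter). This is the first change in a single place among these compounds, and the numbers for the pair stand together, so at this position methoxy and hydrogen cannot be told apart in this read-out. No other measurement here bears on this result. Going by these compounds, whether an amine, a carboxylic acid or a longer chain on this carbon would give a step beyond the scatter remains open, as does methoxy on another carbon of that ring.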